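The compounds below may be only part of what the source reports. "The series", "measured", "known", "first", "only" and "open" are said of these compounds alone.

Working notes on the series. Compound 2 `Oc1ccc(CNc2cc(C(F)(F)F)cc3[nH]ncc23)cc1` gives 75% in an assay for inhibition of Tryptophan 2,3-dioxygenase (Homo sapiens), with stated times of 10 min and 60 min, tested at 10 uM; on this read-out higher numbers stand for a stronger effect at the one concentration tested and lower numbers for a weaker effect; compound 1 `Nc1cccc(CNc2cc(C(F)(F)F)cc3[nH]ncc23)c1` gives 68% and lies within the scatter of it, while compound 3 `O=[N+]([O-])c1ccc(CNc2cc(C(F)(F)F)cc3[nH]ncc23)cc1` gives 47% and lies beyond it, lower. Compound 4 `FC(F)(F)c1cc(NC[C@H]2CCCCN2)c2cn[nH]c2c1` is not yet measured; its change from compound 2 is piperidin-2-yl in place of 4-hydroxyphenyl on a saturated chain carbon bound to a nitrogen on an aromatic ring. The two steps at this same place are a number 7 percentage points higher from compound 1 to compound 2 (within the scatter) and a number 28 percentage points lower from compound 2 to compound 3 (beyond the scatter), so swapping the group on the saturated chain carbon has so far moved the number by at most a modest amount. Going by the values given here, no measured step swaps an aromatic ring for a non-aromatic one, so the direction is uncertain; a modest loss is expected, about a number 25 percentage points lower from compound 2 to compound 4 (beyond the scatter). Compound 4 is thus expected to give 50%, between 25% and 75%.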

Compound 4, a percentage reported as inhibition, at one concentration (the size of the read-out at that concentration, not a potency): 69%
For compound 4 the middle estimate is 19 percentage points below the measured one; the measured number falls inside the stated range.
By their numbers in this assay, from the lowest: compound 3; then compounds 1, 4 and 2 (each within the scatter of the next).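

A non-aromatic ring is accepted at this place on the saturated chain carbon: piperidin-2-yl in place of 4-hydroxyphenyl gives a small change (a number 6 percentage points lower from compound 2 to compound 4 (within the scatter)), and in place of 3-aminophenyl likewise (a number 1 percentage points higher from compound 1 to compound 4 (within the scatter)). An aromatic ring here is thus not needed to keep the read-out, at least among these compounds. No measurement on hand accounts for this.

Open, as far as these compounds go, is whether the ring nitrogen of piperidin-2-yl matters, which a cyclohexyl group would test. Also open, from the compounds shown here alone, is whether the opposite configuration at the stereocentre of piperidin-2-yl reads the same.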